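The source may report more compounds than this note shows. Statements on the series, on what has been measured and on what is new or still open speak of the compounds shown alone.

Working notes on the series. Compound 1 `CCC(=O)NCCCO[C@H]1[C@H](C)[C@@H](O[C@@H]2O[C@H](C)C[C@H](N(C)C)[C@H]2O)[C@](C)(O)C[C@@H](C)CN(C)[C@H](C)[C@@H](O)[C@](C)(O)[C@@H](CC)OC(=O)[C@@H]1C` gives 1.6 in a physicochemical assay for lipophilicity, read by HPLC, measured as chromatographic lipophilicity, at pH 7.4; a higher number here means a more lipophilic compound, a lower number a more polar compound. Compound 2 `CCC(=O)NCCCO[C@H]1[C@H](C)O[C@@H](O[C@H]2[C@H](C)[C@@H](O[C@@H]3O[C@H](C)C[C@H](N(C)C)[C@H]3O)[C@](C)(O)C[C@@H](C)CN(C)[C@H](C)[C@@H](O)[C@](C)(O)[C@@H](CC)OC(=O)[C@@H]2C)C[C@@]1(C)OC` is built on a different core; the difference between the two cores is not broken down here. In this assay compound 2 gives 2.54. Compound 3 `CC[C@H]1OC(=O)[C@H](C)[C@@H](O[C@H]2C[C@@](C)(OC)[C@@H](OCCCNC(=O)COC)[C@H](C)O2)[C@H](C)[C@@H](O[C@@H]2O[C@H](C)C[C@H](N(C)C)[C@H]2O)[C@](C)(O)C[C@@H](C)CN(C)[C@H](C)[C@@H](O)[C@]1(C)O` differs from compound 2 by methoxy in place of methyl on a saturated chain carbon bound to a carbonyl carbon; that change produced a number 0.38 log units lower from compound 2 to compound 3 (beyond the scatter), and in this assay compound 3 gives 2.16. Among the three measured compounds, compound 1 stands lowest. Compound 4 `CC[C@H]1OC(=O)[C@H](C)[C@@H](OCCCNC(=O)COC)[C@H](C)[C@@H](O[C@@H]2O[C@H](C)C[C@H](N(C)C)[C@H]2O)[C@](C)(O)C[C@@H](C)CN(C)[C@H](C)[C@@H](O)[C@]1(C)O`, not yet measured, differs from compound 1 by methoxy in place of methyl on a saturated chain carbon bound to a carbonyl carbon, the same change at the same place. The step is expected to be of similar size to the earlier one: a number 0.38 log units lower from compound 1 to compound 4 (beyond the scatter), resting on a number 0.38 log units lower from compound 2 to compound 3 (beyond the scatter) in this assay. Compound 4 is accordingly estimated at 1.22, with a range from 0.85 to 1.6.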

Compound 4, distribution coefficient: 1.4
The estimate for compound 4 lay 0.18 log units below the measured number; measured number inside the range.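

In this assay, methoxy in place of methyl on a saturated chain carbon bound to a carbonyl carbon gives a number 0.38 log units lower from compound 2 to compound 3 (beyond the scatter), but on the core of compound 1 it gives a number 0.20 log units lower from compound 1 to compound 4 (within the scatter), so a step beyond the scatter on one core is not reproduced beyond the scatter on the other. With a single pair on each core, this does not show that the two cores truly respond differently, nor that the change has no effect on the core of compound 1. No supporting measurement here bears on the reason for this result.

The compounds shown leave open how an amine, a carboxylic acid or a longer chain such as ethoxy would behave at this place on either core. From the compounds shown here alone, whether methoxy in place of methyl would give a step beyond the scatter on any further core also remains open.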